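Oxazole carbonyl replacing acetyl on a tolerant ring nitrogen

The compounds below may be only part of what the source reports. "The series", "measured", "known", "first", "only" and "open" are said of these compounds alone.

Of the compounds shown here, two sharing one core have been tested in an assay on HEK293 cells for agonist activity at Toll-like receptor 8 (Homo sapiens), read by a luciferase reporter, with a stated time of 6 h; on this read-out higher numbers stand for an effect only at larger amounts of compound and lower numbers for an effect already at smaller amounts. Compound 1 `CCCCNc1nc(N)nc2c1CN(C(C)=O)CC2` gives 0.5 uM. Compound 2 `CCCCNc1nc(N)nc2c1CN(Cc1cccc3ccccc13)CC2`, which carries a much larger group on the ring nitrogen, gives 0.43 uM, a number that lies within the usual scatter of that of compound 1, so the two cannot be ranked against each other. Compound 3 `CCCCNc1nc(N)nc2c1CN(C(=O)c1cocn1)CC2` has not yet been measured in this assay. It differs from compound 1 in one place: 1,3-oxazol-4-yl in place of methyl on a carbonyl carbon. Since the two measured compounds show that very different groups at the ring nitrogen give numbers within the scatter of one another, the step of a 1.3-fold lower number from compound 1 to compound 3 (0.10 log units; within the scatter) is expected to be small, with no clear direction beyond the scatter. Compound 3 is therefore estimated at 0.4 uM, with a range from 0.15 uM to 1.2 uM.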

Compound 3, minimum effective concentration: 0.2 uM
For compound 3 the middle estimate is 2.0-fold (0.30 log units) above the measured one, and the stated range covers the measured number.
By their numbers in this assay, from the lowest: compound 3; then compounds 2 and 1 (each within the scatter of the next).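

In this assay, methyl gives way to 1,3-oxazol-4-yl on a carbonyl carbon with a 2.5-fold lower number from compound 1 to compound 3 (0.40 log units; beyond the scatter) at this ring nitrogen, where the earlier two compounds could not be ranked against each other. The position thus does more than accept a change: here a step beyond the scatter appears, in the direction of an effect at smaller amounts, though only a modest one. No measurement is at hand that explains this step or assigns it to any part of the entering group.

From the compounds shown here alone, whether the five-membered aromatic ring or its hetero atoms carry the step remains open, and phenyl or 1,3-thiazol-4-yl on the same carbonyl carbon would bear on that question. Also open, going by these compounds, is whether a saturated ring such as cyclopentyl at that carbon would give a similar number.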